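This account rests on a few compounds, and the source may have more. Where it says the series, first, only, none or still open, it means among the compounds named here.

Of the compounds shown here, two have been measured so far in an ADME assay on a cell-free system (plasma, Homo sapiens) for protein binding, with Plasma (Rattus norvegicus) as the target. Compound 1 `CN1CC(c2ccccc2)n2nc(C(=O)NCc3ccc(F)cc3)c(O)c2C1=O` gives 1.1%, and compound 2 `CNC(=O)c1cc(F)ccc1CNC(=O)c1nn2c(c1O)C(=O)N(C)C[C@@H]2c1ccccc1` gives 12%. Most of each compound is therefore free, and when the two are compared by their unbound fractions, they lie within the usual scatter of each other.

The next compound is compound 3 `CNC(=O)c1cc(F)ccc1CNC(=O)c1nn2c(c1O)C(=O)N(C)C[C@H]2c1ccccc1`. Its difference from compound 2 is this: the two compounds have the same atoms and bonds and differ only in configuration as drawn: 1 of 1 stereo elements differ; a stereocentre at a saturated ring carbon is drawn S in compound 2 and R in compound 3. The two compounds have the same atoms and bonds, and a stereocentre at a saturated ring carbon is drawn S in compound 2 and R in compound 3.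

Going by the values given here, no measured pair in this small set shows what such a change does, so there is no direct guide to its size. Nothing leaves or enters, so compound 2 at 12% is the natural starting point, and no step beyond the scatter is expected in this assay, in either direction. The expected step, no change at the digits printed from compound 2 to compound 3 (within the scatter), is estimated to stay within that scatter. For compound 3 the estimated value is 12%, with an expected range from 3% to 35%.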

Compound 3, plasma protein binding: 12%
Compound 3: the middle estimate sits on the measured number at the digits printed, within the range that was stated.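

Among the compounds so far, this is the first pair that differs in one place, and this assay shows no change at the digits printed from compound 2 to compound 3 (within the scatter). Going by these compounds alone, for the first time, then, there is a direct reading of what swapping the drawn configuration does at this saturated ring carbon: in this pair, going from S to R produces no step beyond the scatter, so the read-out does not separate the two forms. The reading is a clean one, with no added or lost group to complicate it: the fact that compounds 2 and 3 differ only in the configuration as drawn

Still open, as far as these compounds go, is whether the configuration at this ring carbon would count for as little on a compound carrying a different group on the shared core, such as an amine or a carboxylic acid, since one pair cannot show how general the result is. Also open, from the compounds shown here alone, is what an actual change of group at this ring carbon would do to the read-out, for example a longer chain in place of the phenyl ring, as a swap of configuration leaves every atom in the compound unchanged.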